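Moving the Heteroaromatic Amide in a Furoxan Hydroxamate

This account rests on a few compounds, and the source may have more. Where it says the series, first, only, none or still open, it means among the compounds named here.

Two hydroxamic acids bearing a furoxan-containing amide on a shared pyrrolidine core have been examined in a functional assay on HeLa cells (Homo sapiens) for antiproliferative activity, read by MTT assay, with a stated time of 48 h; on this read-out higher numbers stand for weaker inhibition and lower numbers for stronger inhibition. Compound 1 `O=C(N[C@H]1C[C@@H](C(=O)NO)N(S(=O)(=O)c2ccc(Oc3ccccc3)cc2)C1)c1ccc2no[n+]([O-])c2c1` gives 3820 nM in this assay. Compound 2 `COc1ccc(/C=C/C(=O)N2C[C@@H](NC(=O)c3ccc4no[n+]([O-])c4c3)C[C@H]2C(=O)NO)cc1OC` carries a dimethoxycinnamoyl group on the ring nitrogen in place of the sulfonyl group of compound 1; in this assay compound 2 gives 6490 nM. The two numbers lie within the scatter of each other, so neither can be said to differ from the other.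

Compound 3 `COc1ccc(/C=C/C(=O)N2C[C@@H](NC(=O)c3cccc4no[n+]([O-])c34)C[C@H]2C(=O)NO)cc1OC` is the next case. It differs from compound 2 by a group of 10 heavy atoms (6 carbon, 2 nitrogen, 2 oxygen; one five-membered aromatic ring with 3 hetero atoms, one six-membered aromatic ring of carbon only) in place of a group of 10 heavy atoms (6 carbon, 2 nitrogen, 2 oxygen; one five-membered aromatic ring with 3 hetero atoms, one six-membered aromatic ring of carbon only), on a carbonyl carbon; the two share every atom and are joined differently. Among the measured compounds shown here, no measured pair shows such a change, so the direction of the step is unknown. With nothing to set it apart, the step from compound 2 to compound 3 is expected to be small, a 1.1-fold higher number from compound 2 to compound 3 (0.03 log units; within the scatter), not beyond the scatter. Compound 3 is therefore estimated at 7000 nM, between 3000 nM and 16000 nM.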

Compound 3, half-maximal inhibitory concentration: 14100 nM
Compound 3: the middle estimate sits 2.0-fold (0.30 log units) below what was measured; low and high end bracket the measured number.
By their numbers in this assay, from the lowest: compounds 1 and 2 (each within the scatter of the next); then compound 3.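

In this assay, this pair shows that the group on the carbonyl carbon is sensitive to how its atoms are joined, not only to which atoms it holds: with the same atoms, ring types, donors and acceptors, the change still gives a 2.2-fold higher number from compound 2 to compound 3 (0.34 log units; beyond the scatter) and is thus a modest but readable step. Compound 1 and compound 2 could not show this, since both carry the same group there and differ only on the ring nitrogen. No measurement shown here bears on what lies behind the step.

From the compounds shown here alone, whether the same change gives a similar step alongside the sulfonyl group of compound 1 remains open. Also open, going by these compounds, is how a plain phenyl ring or a pyridine ring on that carbonyl carbon would compare with either arrangement.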